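Swapping the Nitrile for Fluorine on the Distal Ring

This account rests on a few compounds, and the source may have more. Where it says the series, first, only, none or still open, it means among the compounds named here.

Of the compounds shown here, three built on one shared core have been measured in an assay on isolated protein for inhibition of ceramide glucosyltransferase (Homo sapiens); on this read-out higher numbers stand for weaker inhibition and lower numbers for stronger inhibition. Compound 1 `Cc1cccc(-c2ccc(COCCCCCN3C[C@H](O)[C@@H](O)[C@H](O)[C@H]3CO)cc2)c1` gives 100 nM, compound 2 `COc1ccccc1-c1ccc(COCCCCCN2C[C@H](O)[C@@H](O)[C@H](O)[C@H]2CO)cc1` gives 50 nM, and compound 3 `N#Cc1ccc(-c2ccc(COCCCCCN3C[C@H](O)[C@@H](O)[C@H](O)[C@H]3CO)cc2)cc1` gives 150 nM. Compound 3 holds the highest of the three numbers: the step of a 1.5-fold higher number from compound 1 to compound 3 (0.18 log units; within the scatter) stays within the scatter, while a 3.0-fold higher number from compound 2 to compound 3 (0.48 log units; beyond the scatter) goes beyond it. Compound 4 `OC[C@@H]1[C@@H](O)[C@H](O)[C@@H](O)CN1CCCCCOCc1ccc(-c2ccccc2F)cc1` differs from compound 3 by 2-fluorophenyl in place of 4-cyanophenyl on an aromatic carbon. The same position has been varied before, with a 2.0-fold lower number from compound 1 to compound 2 (0.30 log units; within the scatter) small and a 3.0-fold higher number from compound 2 to compound 3 (0.48 log units; beyond the scatter) modest, so only a modest shift in this assay is expected here, in the direction of a lower number. Compound 4 is therefore expected to give 80 nM (range 35 nM to 200 nM), which is expected to amount to a 1.9-fold lower number from compound 3 to compound 4 (0.27 log units; within the scatter).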

Compound 4, half-maximal inhibitory concentration: 75 nM
The estimate for compound 4 lay 1.1-fold (0.03 log units) above the measured number; the measured number falls inside the stated range.
By their numbers in this assay, from the lowest: compounds 2, 4, 1 and 3 (each within the scatter of the next, the first and the last beyond it).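

The 2-fluorophenyl group leaves compound 4 within the scatter of every earlier compound in this assay: a 2.0-fold lower number from compound 3 to compound 4 (0.30 log units; within the scatter), a 1.3-fold lower number from compound 1 to compound 4 (0.12 log units; within the scatter), and, for fluoro in place of methoxy, a 1.5-fold higher number from compound 2 to compound 4 (0.18 log units; within the scatter). This position therefore tolerates a group without the hydrogen-bond acceptor of the 4-cyanophenyl group, and compound 4 separates from none of the others. No measurement here gives a reason for these steps. Open, going by these compounds, is how a 3-fluorophenyl or 4-fluorophenyl group would compare with compound 4. On these data alone, an amine or a carboxylic acid at this position also remains open.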